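From Compound 2 to Compound 3 in One Assay

A few compounds are considered here, and "the series" means these few. Any claim that something is new, unique, unknown or untested is made for them only; others in the source may bear on it.

Compound 1, `CCNC(=O)NS(=O)(=O)c1ccc(-n2nc(C)cc2C)cc1`: < 1%
Compound 2, `Cc1cc(C(=O)O)nn1-c1ccc(S(=O)(=O)NC(=O)NCc2ccccc2)cc1`: 0%

In a functional assay on the whole organism (blood, strain albino) with Mus musculus as the target, with stated times of 6 days and 4 h, at a dose of 0.4 mmol/kg by the oral route (a higher number here means more inhibition at the dose given (going by the name of the read-out), a lower number less inhibition), compound 1 gives only a limit of the assay, < 1%; that limit is the one at which one of the two values sits (the limit of < 1% in this assay, at which 1 of the 2 values shown sits). Compound 2 gives 0% in this assay, the only number shown. Compound 3, `CCNC(=O)NS(=O)(=O)c1ccc(-n2nc(C(=O)O)cc2C)cc1`, has yet to be measured and differs from compound 2 by methyl in place of phenyl on a saturated chain carbon bound to an amide-type nitrogen. Among the measured compounds shown here, no step between measured compounds is available, so the step is expected to be none beyond the scatter, a number 2 percentage points higher from compound 2 to compound 3 (within the scatter). Compound 3 is estimated at 2%, between 0% and 12%.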

Compound 3, a percentage reported as inhibition, in the whole organism at one dose (the size of the read-out at that dose, not a potency): 0%
Compound 3: the middle estimate sits 2 percentage points above what was measured; the range from low to high includes it.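

In this assay, methyl in place of phenyl on a saturated chain carbon bound to an amide-type nitrogen brings no change at the digits printed from compound 2 to compound 3 (within the scatter). Going from benzyl to ethyl at this place therefore does not separate the two carboxy compounds, and neither shows inhibition at the dose given. For compound 1 the assay gives only a limit, and its step to compound 3, carboxy in place of methyl on an aromatic carbon, cannot be read: the limit of < 1% in this assay, at which 1 of the 3 values shown sits.

From the compounds shown here alone, whether any group at this place can give a measurable read-out stays open. So does the effect of a longer chain or an amine there, or of an ester in place of the carboxy group.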